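Series notes: cyclohexylmethyl in place of isopropyl

The compounds below may be only part of what the source reports. "The series", "measured", "known", "first", "only" and "open" are said of these compounds alone.

Three members of the series have been measured so far: compound 1 `CC(C)c1cc(Cn2ccc3cc(OCC(=O)O)ccc32)ccc1O`, compound 2 `Cc1cn(Cc2ccc(O)c(C(C)C)c2)c2ccc(OCC(=O)O)cc12` and compound 3 `Cc1cn(Cc2ccc(O)c(C(C)C)c2)c2c(C)cc(OCC(=O)O)cc12`. In an assay on HeLa cells for displacement of a labelled ligand from thyroid hormone receptor beta (Homo sapiens) (on this read-out higher numbers stand for weaker inhibition and lower numbers for stronger inhibition), compound 1 gives 1.04 nM, compound 2 gives 0.38 nM and compound 3 gives 0.18 nM. Two steps are known, each a methyl in place of hydrogen on an aromatic carbon of the shared core: a 2.7-fold lower number from compound 1 to compound 2 (0.44 log units; beyond the scatter) and a 2.1-fold lower number from compound 2 to compound 3 (0.32 log units; beyond the scatter). Compound 2 therefore stands second highest of the three numbers in this assay, with compound 3 the nearer neighbour and compound 1 the further one.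

The next compound, compound 4 `Cc1cn(Cc2ccc(O)c(CC3CCCCC3)c2)c2ccc(OCC(=O)O)cc12`, changes a different place on compound 2: cyclohexylmethyl in place of isopropyl on an aromatic carbon. Neither measured step touches this position; both concern methyl on the core, so the series offers no direct reading of what a larger group here does. With nothing to anchor it, the expected step in this assay is a 2.4-fold higher number from compound 2 to compound 4 (0.37 log units; beyond the scatter), that is a small loss, possibly within the scatter. Compound 4 is accordingly estimated at 0.9 nM in this assay. The range for compound 4 is expected to run from 0.3 nM to 3 nM.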

Compound 4, inhibition constant: 1.11 nM
Compound 4: the middle estimate sits 1.2-fold (0.09 log units) below what was measured; measured number inside the range.
By their numbers in this assay, from the lowest: compound 3; then compound 2; then compounds 1 and 4 (each within the scatter of the next).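

This position, ortho to a hydroxy group, now has its first reading: in this assay, cyclohexylmethyl in place of isopropyl gives a 2.9-fold higher number from compound 2 to compound 4 (0.47 log units; beyond the scatter), a modest step that runs in the opposite direction to the two methyl steps on the shared core. The position therefore accepts a group of 7 heavy atoms carrying a six-membered non-aromatic ring in place of one of 3 heavy atoms and no ring, at a modest cost in this read-out, with compound 4 still giving 1.11 nM. No measurement available here accounts for the direction or size of this step.

A single replacement cannot separate the contribution of the ring from that of the added carbon count, so a phenyl, a cyclopropyl or an open chain such as n-hexyl at this position would each be needed to show which feature tracks the change. Also open, going by these compounds, is whether the same replacement gives a step of similar size on compound 3, and whether a ring bearing an amine, such as piperidinylmethyl, would be accepted here.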